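A Long-Chain Carbamate Series Keeps Its Half-Life

A few compounds are considered here, and "the series" means these few. Any claim that something is new, unique, unknown or untested is made for them only; others in the source may bear on it.

Compound 1, `CCCCCCCCCCNC(=O)Oc1ccc(Cl)cc1C(=O)Nc1ccc(Cl)cc1`: 64 h
Compound 2, `CCCCCCCCCCCNC(=O)Oc1ccc(Cl)cc1C(=O)Nc1ccc(Cl)cc1`: 64 h
Compound 3, `CCCCCCCCCCNC(=O)Oc1ccc(Cl)cc1C(=O)Nc1ccc(Cl)c(Cl)c1`: 64 h

In an ADME assay for metabolic stability, read by HPLC, at pH 7 (a lower number here means that the compound disappears faster, a higher number that the compound lasts longer), compound 1 gives 64 h. Compound 2 differs from it by methyl in place of hydrogen on a saturated chain carbon, ten or more bonds along the chain from an amide-type nitrogen, and that step, no change at the digits printed from compound 1 to compound 2 (within the scatter), left the reading flat. Compound 3 instead carries chloro in place of hydrogen on an aromatic carbon, and this step, no change at the digits printed from compound 1 to compound 3 (within the scatter), was flat as well. Compound 4, `CCCCCCCCCCCNC(=O)Oc1ccc(Cl)cc1C(=O)Nc1ccc(Cl)c(Cl)c1`, has not yet been measured in this assay. It differs from compound 3 by methyl in place of hydrogen on a saturated chain carbon, ten or more bonds along the chain from an amide-type nitrogen, the same change that took compound 1 to compound 2, now made on the core of compound 3. Since that same change gave no change at the digits printed from compound 1 to compound 2 (within the scatter), a similarly flat step is expected here, no change at the digits printed from compound 3 to compound 4 (within the scatter). Compound 4 is therefore expected to give about 64 h, most likely between 32 h and 128 h.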

Compound 4, half-life: 64 h
For compound 4 middle estimate and measured number coincide at the digits printed; the range from low to high includes it.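

In this assay the methyl change behaves alike on both cores, with no change at the digits printed from compound 3 to compound 4 (within the scatter) beside the earlier step: the same change on two cores in this assay, no change at the digits printed (within the scatter) from compound 1 to compound 2 and no change at the digits printed (within the scatter) from compound 3 to compound 4, 1.0-fold (0.00 log units) apart, within the scatter of two such steps

The chloro change also behaves alike on both cores, with no change at the digits printed from compound 2 to compound 4 (within the scatter) beside its earlier step: the same change on two cores in this assay, no change at the digits printed (within the scatter) from compound 1 to compound 3 and no change at the digits printed (within the scatter) from compound 2 to compound 4, 1.0-fold (0.00 log units) apart, within the scatter of two such steps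

This shows that two flat steps carry over between these cores, but not that a change that truly moved the half-life would carry over in the same way.

The compounds shown leave open whether a much shorter chain, or a chain carrying an amine or a carboxylic acid, would move the half-life at all.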